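Fluoro for Cyano: One Change, One Number to Predict

The source may hold more compounds than are shown below. What is called first, only, known or untested is meant among the compounds shown, and "the series" means these compounds.

Three compounds of this set share one core and carry different groups at its far end. In a functional assay on A549 cells (Homo sapiens) for cytotoxicity, read by MTT assay, with a stated time of 72 h (on this read-out lower numbers stand for stronger inhibition and higher numbers for weaker inhibition), compound 1 `CNC(=O)c1cc(Oc2ccc(/C=C/C(=O)c3ccc([N+](=O)[O-])cc3)cc2)ccn1` has "not determined" (no result reported), and in this assay compound 3 `CNC(=O)c1cc(Oc2ccc(/C=C/C(=O)c3ccc(Cl)cc3)cc2)ccn1` likewise has "not determined" (no result reported). In this assay, going by the values given here, compound 2 `CNC(=O)c1cc(Oc2ccc(C(=O)/C=C/c3ccc(C#N)cc3)cc2)ccn1` gives 26400 nM, which is the only number in the set, so compound 2 stands alone: there is no second value to rank it against, and no step between measured compounds is available.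

Compound 4 `CNC(=O)c1cc(Oc2ccc(C(=O)/C=C/c3ccc(F)cc3)cc2)ccn1` is the next point. Compared with compound 2, the change is fluoro in place of cyano on an aromatic carbon. Among the compounds with values here, no measured pair in this set shows what such an exchange does, and the cyano compound is the one point of reference. With nothing to point either way, the step from compound 2 to compound 4 is expected to be small, within the usual scatter, as a 1.1-fold higher number from compound 2 to compound 4 (0.06 log units; within the scatter) expresses. Compound 4 is therefore estimated at 30000 nM in this assay, with a plausible range from 10000 nM to 90000 nM.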

Compound 4, half-maximal inhibitory concentration: 18600 nM
Compound 4: the middle estimate sits 1.6-fold (0.21 log units) above what was measured, within the range that was stated.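

Replacing the 4-cyanophenyl end with 4-fluorophenyl gives a 1.4-fold lower number from compound 2 to compound 4 (0.15 log units; within the scatter) in this assay. Going by these compounds alone, this is the first measured step in the set, and it shows that on this aromatic carbon, a nitrile and a fluoro group cannot be told apart in this cell assay, since the two compounds lie within the scatter of each other. Nothing measured here bears on why that is, so the result stands without an explanation.

Going by these compounds, whether the same holds for a very different group at this place, such as an amine, a carboxylic acid or a longer chain, stays open. Compound 1 and compound 3 have no numbers, so any steps to them cannot be read, and the nitro and chloro groups they carry remain unplaced beside compound 2 and compound 4.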